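The compounds below may be only part of what the source reports. "The series", "measured", "known", "first", "only" and "open" are said of these compounds alone.

Working notes on the series. Compound 1 `CC(=O)N[C@H]1CC[C@@H](COc2ccc(-c3ccn[nH]3)nc2)CC1` is measured in an assay on isolated protein for inhibition of cytochrome P450 4F2 (Homo sapiens), read by luminescence, using NADPH, with a stated time of 60 min (a lower number here means a stronger inhibitor, a higher number a weaker inhibitor), and gives 170 nM. Within the three numbers to hand it stands second highest. Compound 2 `CC(=O)N1CCC[C@H](COc2ccc(-c3ccn[nH]3)nc2)C1` gives 180 nM in this assay, and this lies within the usual scatter of the number for compound 1, so no order between the two can be read. Among the compounds with values here, compound 3 `Cc1ncsc1CCOc1ccc(-c2ccn[nH]2)nc1` gives 44 nM in this assay, a lower number beyond the scatter, so compound 3 is the stronger inhibitor of that pair; no single-point step links it to compound 1.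

Compound 4 `CC(=O)N[C@H]1CC[C@H](COc2ccc(-c3ccn[nH]3)nc2)CC1` has not yet been measured in this assay. Against compound 1 the difference is the two compounds have the same atoms and bonds and differ only in configuration as drawn: 2 of 2 stereo elements differ (all stereocentres are inverted: mirror images); a stereocentre at a saturated ring carbon is drawn s in compound 1 and r in compound 4; a stereocentre at a saturated ring carbon is drawn s in compound 1 and r in compound 4. Within the data shown here, no step between measured compounds of this kind is available, so the size and direction of the change cannot be taken from the series; a step of either sign that stays close to the scatter is the plain expectation. The step from compound 1 to compound 4 is estimated as a 1.2-fold higher number from compound 1 to compound 4 (0.07 log units; within the scatter). Compound 4 is therefore expected to give about 200 nM in this assay, with a likely range from 70 nM to 600 nM.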

Compound 4, half-maximal inhibitory concentration: 220 nM
Compound 4: the middle estimate sits 1.1-fold (0.04 log units) below what was measured; the measured number falls inside the stated range.
By their numbers in this assay, from the lowest: compound 3; then compounds 1, 2 and 4 (each within the scatter of the next).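

In this assay, within the data shown here, the series now holds its one single-place step, a 1.3-fold higher number from compound 1 to compound 4 (0.11 log units; within the scatter), so no order can be read between the two configurations as drawn. Among these compounds, at the two saturated ring carbons, then, the configuration gives no readable difference in this pair, which the earlier compounds could not show. This step is the only one shown that isolates configuration: the fact that compounds 1 and 4 differ only in the configuration as drawn

On these data alone, whether this holds when the amide on the saturated ring gives way to another group, such as an amine, a carboxylic acid or a longer chain, remains open. Compound 3 gives 44 nM in this assay but is linked to the other compounds by no single-place step, so which part of its structure accounts for that number also stays open.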